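The compounds below may be only part of what the source reports. "The series", "measured", "known", "first", "only" and "open" are said of these compounds alone.

Measured compounds:
compound 1, `COc1ccc(CNc2nc([Se]C)nc3ccccc23)cc1` — > 100000 nM
compound 2, `COc1ccc(CNc2nc([SeH])nc3ccccc23)cc1` — > 100000 nM

In a functional assay on MCF7 cells (Homo sapiens) for cytotoxicity, read by MTT assay, with a stated time of 72 h (on this read-out higher numbers stand for lower toxicity in this test and lower numbers for higher toxicity in this test), compound 1 gives > 100000 nM, which is a limit of the assay and not a number. Compound 2 likewise gives > 100000 nM in this assay, again a limit. Among the compounds with values here, the one measured step, a step that the two limits leave unreadable from compound 1 to compound 2, is therefore of unreadable size, since both of its ends sit at the limit of > 100000 nM in this assay, at which 2 of the 2 values shown sit.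

Compound 3, `C[Se]c1nc(NCc2ccccc2)c2ccccc2n1`, is to be measured next. It differs from compound 1 by hydrogen in place of methoxy on an aromatic carbon. Within the data shown here, no measured step touches this position, and the only step available, a step that the two limits leave unreadable from compound 1 to compound 2, gives no readable size, so nothing in the numbers points to a direction for this change. The step that the limit leaves unreadable from compound 1 to compound 3 is expected to be small or nothing beyond the scatter, with compound 3 most likely again stopping at the limit. Compound 3 is thus estimated at 150000 nM, within 40000 nM to 600000 nM.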

Compound 3, concentration lethal to 50% of the cells: > 100000 nM
Compound 3 was reported as a limit; the forecaster's own chance of this, stated with the estimate: 80%; the middle value does not contradict the limit.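

Compound 1 and compound 3 both end at a limit and not at a number, so no size can be read for the step between them: the limit of > 100000 nM in this assay, at which 3 of the 3 values shown sit.

The compounds shown leave open whether hydrogen in place of methoxy or of methyl changes the result in this assay.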